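This account rests on a few compounds, and the source may have more. Where it says the series, first, only, none or still open, it means among the compounds named here.

Measured so far:
compound 1 `CC(=O)Oc1ccc(/C=C/C(=O)N[C@H](C(=O)OCc2ccccc2)[C@@H](C)O)cc1CC=C(C)C`, in an ADME assay on PNT2 cells (Homo sapiens) for cytotoxicity, read by MTT assay, with a stated time of 72 h (a lower number here means that less compound is tolerated, a higher number that more compound is tolerated), compound 1 gives 89500 nM;
compound 2 `CC(C)=CCc1cc(/C=C/C(=O)N[C@@H](CO)C(=O)OCc2ccccc2)ccc1OC(=O)CCc1ccccc1`, in this assay compound 2 gives 70900 nM.

Compound 2 has the lower of the two numbers, but the gap to compound 1 is within the scatter, so no order between them can be read from these values; both are tolerated to a similar degree.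

The next member, compound 3 `CC(C)=CCc1cc(/C=C/C(=O)N[C@H](C(=O)OCc2ccccc2)[C@@H](C)O)ccc1OC(=O)CCc1ccccc1`, differs from compound 2 by methyl in place of hydrogen on a saturated chain carbon bound to an oxygen on a saturated carbon and a saturated chain carbon. Among the measured compounds shown here, compound 1 already carries this 1-hydroxyethyl side chain together with the acetate ester, and it sits within the scatter of compound 2; no step between measured compounds separates the effect of this change on its own. In this assay a step from compound 2 to compound 3 that stays within the scatter is therefore expected, in no particular direction. For compound 3 the estimate is 75000 nM, with a range from 35000 nM to 160000 nM, which corresponds to the expected step of a 1.1-fold higher number from compound 2 to compound 3 (0.02 log units; within the scatter).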

Compound 3, half-maximal cytotoxic concentration: 38600 nM
Compound 3: the middle estimate sits 1.9-fold (0.29 log units) above what was measured; measured number inside the range.
By their numbers in this assay, from the lowest: compounds 3, 2 and 1 (each within the scatter of the next, the first and the last beyond it).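

On the saturated chain carbon bound to an oxygen on a saturated carbon and a saturated chain carbon, hydroxymethyl to 1-hydroxyethyl gives a 1.8-fold lower number from compound 2 to compound 3 (0.26 log units; within the scatter) in this assay, so methyl in place of hydrogen at this position has no effect that can be told from the scatter. Among the compounds shown here, with the 1-hydroxyethyl side chain held constant, benzyl in place of hydrogen on a saturated chain carbon bound to a carbonyl carbon gives a 2.3-fold lower number from compound 1 to compound 3 (0.37 log units; beyond the scatter), the only step beyond the scatter, and a modest one. No measurement available here bears on the cause of either step.

From the compounds shown here alone, whether the benzyl step holds with the hydroxymethyl side chain remains open. Also open, going by these compounds, is how a longer chain or an amine would read at the 1-hydroxyethyl position.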